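The source may hold more compounds than are shown below. What is called first, only, known or untested is meant among the compounds shown, and "the series" means these compounds.

Compound 1 `O=C1O[C@@H](CN2CCC(O)CC2)CN1c1ccc(-n2cc(-c3ccccn3)cn2)c(F)c1` is the starting point of this step. For the measured compounds named here, in a physicochemical assay for solubility, read by HPLC, with a stated time of 24 h (a lower number here means a less soluble compound, a higher number a more soluble compound), compound 1 gives 45900 nM, the lowest of the two numbers measured so far. Its nearest neighbour is compound 2 `CCC(=O)NC[C@H]1CN(c2ccc(-n3cc(-c4ccccn4)cn3)c(F)c2)C(=O)O1`, which in this assay gives 147000 nM; the step of a 3.2-fold higher number from compound 1 to compound 2 (0.51 log units; beyond the scatter) comes from exchanging one group on a saturated chain carbon bound to a saturated ring carbon.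

Compound 3 `O=C1O[C@@H](CNC(=O)C(F)(F)F)CN1c1ccc(-n2cc(-c3ccccn3)cn2)c(F)c1` has not yet been measured. The change from compound 1 to compound 3 is ((trifluoromethyl)carbonyl)amino in place of 4-hydroxypiperidin-1-yl on a saturated chain carbon bound to a saturated ring carbon. This is the same kind of exchange seen from compound 1 to compound 2: a group bound through a ring nitrogen leaves, and an amide group enters at the same place. Going by the values given here, the one measured step that bears on it, a 3.2-fold higher number from compound 1 to compound 2 (0.51 log units; beyond the scatter), was modest and upward. The expectation is therefore a rise of similar direction for compound 3, a 2.0-fold higher number from compound 1 to compound 3 (0.29 log units; within the scatter), though with no second measured amide of this kind the size is uncertain. In this assay compound 3 is expected to give about 90000 nM, with a likely range from 35000 nM to 230000 nM.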

Compound 3, solubility: 114000 nM
The estimate for compound 3 lay 1.3-fold (0.10 log units) below the measured number; the range from low to high includes it.
By their numbers in this assay, from the lowest: compound 1; then compounds 3 and 2 (each within the scatter of the next).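

In this assay, the step of a 2.5-fold higher number from compound 1 to compound 3 (0.40 log units; beyond the scatter) gives a second amide on the saturated chain carbon that stands clear of the 4-hydroxypiperidin-1-yl compound, so the rise seen with propanoylamino is no longer a single case, and none of the three compounds shown goes against it. The new comparison is on the carbonyl carbon, where the step of a 1.3-fold lower number from compound 2 to compound 3 (0.11 log units; within the scatter) stays within the usual scatter, so ethyl and trifluoromethyl at that place cannot be told apart in this read-out, even though their atoms differ. Nothing shown here offers an explanation for either step.

The compounds shown leave open whether the rise belongs to the amide itself or simply to the loss of 4-hydroxypiperidin-1-yl, since a simple primary amine or a carboxylic acid on the same saturated chain carbon would be needed to separate the two. They also leave open how far the carbonyl carbon tolerates other groups, such as a longer chain like hexanoyl or a phenyl ring.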